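This account rests on a few compounds, and the source may have more. Where it says the series, first, only, none or still open, it means among the compounds named here.

Series notes, step from compound 2 to compound 4.

Three compounds carry numbers in a functional assay on HBL-100 cells (Homo sapiens) for antiproliferative activity, read by sulforhodamine B assay, with a stated time of 48 h; on this read-out lower numbers stand for stronger inhibition of growth and higher numbers for weaker inhibition of growth. Compound 1 `CC1(C)O[C@H]2[C@H](OCc3noc(-c4ccc([N+](=O)[O-])cc4)n3)O[C@H](CO)[C@H]2O1` gives 99000 nM. Compound 2 `COc1cc(-c2nc(CO[C@@H]3O[C@H](CSc4ncn[nH]4)[C@H]4OC5(CCCC5)O[C@@H]34)no2)cc(OC)c1OC` gives 34000 nM. Compound 3 `COc1cc(-c2nc(CO[C@@H]3O[C@H](CSc4nnc(N)s4)[C@H]4OC5(CCCC5)O[C@@H]34)no2)cc(OC)c1OC` gives 33000 nM. On these numbers compound 2 stands second highest of three: compound 3 is the nearest, with a number within the scatter of it, and compound 1 is the furthest, with a higher number beyond the scatter.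

Going by the values given here, the only single-point step measured is a 1.0-fold lower number from compound 2 to compound 3 (0.01 log units; within the scatter), which exchanges the group on the sulfur and leaves the number where it was.

Compound 4 `O=[N+]([O-])c1ccc(-c2nc(CO[C@@H]3O[C@H](CSc4ncn[nH]4)[C@H]4OC5(CCCC5)O[C@@H]34)no2)cc1` differs from compound 2 at the aromatic carbon of the five-membered aromatic ring with 2 nitrogen and 1 oxygen: 4-nitrophenyl in place of 3,4,5-trimethoxyphenyl on an aromatic carbon. Among the compounds with values here, no measured step covers this change. Compound 1 also bears 4-nitrophenyl at that position and gives a higher number than compound 2, but compound 1 differs from compound 2 in more than one place, so its value only hints at a direction. A step toward a higher number, of modest size, is therefore expected in this assay, the estimated step being a 1.8-fold higher number from compound 2 to compound 4 (0.25 log units; within the scatter).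

Compound 4 is expected to give about 60000 nM, in the range 25000 nM to 150000 nM.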

Compound 4, concentration for 50% growth inhibition: 24000 nM
The estimate for compound 4 lay 2.5-fold (0.40 log units) above the measured number, and the stated range ends above it.
By their numbers in this assay, from the lowest: compounds 4, 3 and 2 (each within the scatter of the next); then compound 1.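

In this assay, the step on the aromatic carbon of the five-membered ring, with 4-nitrophenyl in place of 3,4,5-trimethoxyphenyl, is a 1.4-fold lower number from compound 2 to compound 4 (0.15 log units; within the scatter). This position, the second place varied on the scaffold of compound 2 after the group on the sulfur, therefore accepts an exchange of the whole aryl group without a change beyond the scatter, and both single-place steps now printed lie within it. No measurement at hand accounts for this outcome.

From the compounds shown here alone, whether a plain phenyl, an aminophenyl or a benzoic acid at this position would leave the scatter stays open, as does whether 4-nitrophenyl behaves the same way with 5-amino-1,3,4-thiadiazol-2-yl on the sulfur. What sets compound 1 apart cannot be read from these compounds, since it differs from each of the others in more than one place.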